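The source may hold more compounds than are shown below. What is called first, only, known or untested is meant among the compounds shown, and "the series" means these compounds.

Working notes on the series. Of the compounds shown here, two have been measured in an assay on isolated protein for inhibition of phosphodiesterase 4A (Sus scrofa); on this read-out lower numbers stand for stronger inhibition and higher numbers for weaker inhibition. Compound 1 `COc1ccc(C(=O)Nc2cccnc2)cc1OC1CCCC1` gives 550 nM in this assay. Compound 2 `COc1ccc(C(=O)Nc2c(F)cnc(F)c2F)cc1OC1CCCC1`, which carries three fluoro groups on the amide-bearing aromatic ring, gives 85 nM in this assay. Compound 2 thus holds the lower of the two numbers seen so far, and the gap to compound 1 lies beyond the usual scatter of repeated measurements; as only these two values exist, nothing can be said about which of the three fluoro groups accounts for the difference, nor whether the change runs evenly with each added fluoro.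

The next compound, compound 3 `COc1ccc(C(=O)Nc2c(F)c(F)nc(F)c2F)cc1OC1CCCC1`, differs from compound 2 in one place: fluoro in place of hydrogen on an aromatic carbon. This completes the fluoro substitution of the ring. For the measured compounds named here, no step between measured compounds exists for this kind of change, so the expectation rests only on the two values above. The move from compound 1 to compound 2 shows that fluoro groups on this ring are compatible with, and here accompany, a lower number, but a fourth one is a smaller alteration than the first three, and the expected step from compound 2 to compound 3, a 1.2-fold lower number from compound 2 to compound 3 (0.08 log units; within the scatter), is taken to be small, in either direction, and not clearly beyond the scatter. For compound 3 the estimated value in this assay is 70 nM, with an expected range from 25 nM to 200 nM.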

Compound 3, half-maximal inhibitory concentration: 550 nM
Compound 3: middle estimate off by 7.9-fold (0.90 log units), on the low side, and the stated range ends below it.
By their numbers in this assay, from the lowest: compound 2; then compounds 1 and 3 (each within the scatter of the next).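

Fluoro in place of hydrogen on the aromatic carbon next to the ring nitrogen gives a 6.5-fold higher number from compound 2 to compound 3 (0.81 log units; beyond the scatter) in this assay, so a change of one heavy atom at this position is enough to move the number beyond the scatter. For the compounds shown here, this is the first step between compounds that differ in one place, and it shows that a further fluoro on this ring does not go with a lower number here: the hydrogen at this position in compound 2 goes with the lowest number of the series so far, and the step to the fluoro is a clear loss of inhibition rather than a small shift in either direction. No measurement available here bears on why the number changes at this position.

As far as these compounds go, it remains open whether the step belongs to fluoro in particular or to any replacement of this hydrogen, as a chloro, a methyl or an amine on the same carbon would show. From the compounds shown here alone, it is also open whether the same fluoro gives a step of similar size when the other three fluoro groups on the ring are absent, and which of those three goes with the lower number of compound 2.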